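The source may report more compounds than this note shows. Statements on the series, on what has been measured and on what is new or still open speak of the compounds shown alone.

Measured in an ADME assay on MT4 cells (Homo sapiens) for cytotoxicity, read by MTT assay, with a stated time of 4 days; a lower number here means that less compound is tolerated, a higher number that more compound is tolerated:
- Compound 1 `CCN(C)c1nc(Cc2c(F)cccc2F)cc(=O)[nH]1`: > 89000 nM
- Compound 2 `CC(C)N(C)c1nc(Cc2c(F)cccc2F)cc(=O)[nH]1`: 85000 nM

Going by the values given here, compound 2, at 85000 nM, holds the only exact number so far, so it cannot yet be ranked against a series. Compound 1 gives > 89000 nM, which is a limit of the assay and not a number.

The next compound to be tested is compound 3 `CCCN(C)c1nc(Cc2c(F)cccc2F)cc(=O)[nH]1`. It has the same atoms as compound 2, joined differently: propyl in place of isopropyl on a nitrogen on an aromatic ring. Compound 3 carries propyl where compound 2 carries isopropyl, on the same nitrogen.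

Among the compounds with values here, only one measured step bears on this change. It is an at least 1.0-fold lower number from compound 1 to compound 2 (0.01 log units; that floor lies within the scatter), a methyl in place of a hydrogen on a saturated chain carbon bound to that nitrogen. It is a different change at the same side chain, so it is a weak guide. No step beyond the scatter is expected in this assay because an at least 1.0-fold lower number from compound 1 to compound 2 (0.01 log units; that floor lies within the scatter) stayed within it. The expected result is a 1.1-fold lower number from compound 2 to compound 3 (0.03 log units; within the scatter), with no clear direction. For compound 3 the estimate is 80000 nM, with an expected range of 38000 nM to 130000 nM.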

Compound 3, half-maximal cytotoxic concentration: 85000 nM
Compound 3: middle estimate off by 1.1-fold (0.03 log units), on the low side; the range from low to high includes it.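

In this assay, putting propyl in place of isopropyl on this nitrogen gives no change at the digits printed from compound 2 to compound 3 (within the scatter), so for these two groups, which have the same atoms joined differently, the way the chain is joined makes no visible difference to how much compound the cells tolerate. Compound 1 gives > 89000 nM, which is a limit of the assay and not a number. The remaining step, an at least 1.0-fold lower number from compound 1 to compound 3 (0.01 log units; that floor lies within the scatter), offers only a floor and no true size, because one end of it stands at a limit: the limit of > 89000 nM in this assay, at which 1 of the 3 values shown sits.

From the compounds shown here alone, all the groups on this nitrogen so far are short saturated carbon chains, so it remains open whether any change here can clearly alter the tolerated concentration. A longer chain such as butyl, a ring such as cyclopropyl, or a chain ending in an amine or a carboxylic acid would test whether this flat result holds once the group differs by more than the arrangement of its carbons.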